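A few compounds are considered here, and "the series" means these few. Any claim that something is new, unique, unknown or untested is made for them only; others in the source may bear on it.

For the measured compounds named here, compound 2 `Nc1nc(N)c2nc(O)n(Cc3ccccc3)c2n1` gives 10 uM in a functional assay (spleen, spleen) for activation, with Mus musculus as the target (a lower number here means that less compound is needed, a higher number that more compound is needed for the effect), the highest of the two numbers measured so far; its nearest neighbour, compound 1 `Nc1nc(SCc2ccccc2)nc2c1nc(O)n2Cc1ccccc1`, gives 0.1 uM. Compound 3 `Nc1nc(S)nc2c1nc(O)n2Cc1ccccc1` differs from compound 2 in one place: sulfanyl in place of amino on an aromatic carbon. Going by the values given here, the one measured step that bears on this is a 100-fold higher number from compound 1 to compound 2 (2.00 log units; beyond the scatter), a large change at the same aromatic carbon. Sulfanyl carries one sulfur, as benzylsulfanyl does, but none of the benzyl part, so a partial recovery seems plausible. Compound 3 is expected to move by a 3.3-fold lower number from compound 2 to compound 3 (0.52 log units; beyond the scatter). Compound 3 is estimated at 3 uM, within 0.5 uM to 30 uM.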

Compound 3, minimum effective concentration: 10 uM
Compound 3: middle estimate off by 3.3-fold (0.52 log units), on the low side; the measured number falls inside the stated range.
By their numbers in this assay, from the lowest: compound 1; then compounds 2 and 3 (each within the scatter of the next).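

In this assay, sulfanyl in place of amino on this aromatic carbon gives no change at the digits printed from compound 2 to compound 3 (within the scatter), so the sulfur alone brings no recovery at this position. Hydrogen in place of benzyl on the sulfur gives a 100-fold higher number from compound 1 to compound 3 (2.00 log units; beyond the scatter), which ties the low number of compound 1 to the whole benzylsulfanyl group rather than to its sulfur. No measurement shown here explains this result. As far as these compounds go, it remains open whether the benzyl part needs a sulfur link at all, as benzylamino or benzyloxy on this carbon would show. A methyl or ethyl group on the sulfur would show whether a shorter chain is enough.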